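Moving the alkoxy group on the benzyl ether of compound 3

A few compounds are considered here, and "the series" means these few. Any claim that something is new, unique, unknown or untested is made for them only; others in the source may bear on it.

Compound 3 `COc1ccccc1COc1ccccc1OCCNCCOc1c(OC)cccc1OC` is one of three close analogues measured in a functional assay on PC-3 cells (Homo sapiens) for cytotoxicity, read by sulforhodamine B assay; a lower number here means that less compound is tolerated, a higher number that more compound is tolerated. In this assay compound 3 gives 100000 nM; compound 2 `COc1cccc(OC)c1OCCNCCOc1ccccc1OCc1ccccc1Cl` gives 58900 nM and compound 1 `COc1cccc(OC)c1OCCNCCOc1ccccc1OCc1ccccc1` gives 193000 nM. Compound 3 sits second highest of the three, but its gaps to both neighbours are within the scatter, as the steps of a 1.9-fold lower number from compound 1 to compound 3 (0.29 log units; within the scatter) and a 1.7-fold higher number from compound 2 to compound 3 (0.23 log units; within the scatter) show. Among the compounds with values here, the only step beyond the scatter is a 3.3-fold lower number from compound 1 to compound 2 (0.52 log units; beyond the scatter). Compound 4 `CCOc1ccc(COc2ccccc2OCCNCCOc2c(OC)cccc2OC)cc1` differs from compound 3 by 4-ethoxyphenyl in place of 2-methoxyphenyl on a saturated chain carbon bound to an oxygen on an aromatic ring. Within the data shown here, no measured step bears directly on this change; the steps seen so far concern a single substituent on that benzyl ring and were small or modest. The estimate for compound 4 in this assay is therefore a value close to that of compound 3, with a step of a 1.3-fold lower number from compound 3 to compound 4 (0.10 log units; within the scatter) expected to remain within the scatter, giving an expected 80000 nM in a range from 30000 nM to 200000 nM.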

Compound 4, concentration lethal to 50% of the cells: 51300 nM
Compound 4: the middle estimate sits 1.6-fold (0.19 log units) above what was measured; the range from low to high includes it.
By their numbers in this assay, from the lowest: compounds 4, 2, 3 and 1 (each within the scatter of the next, the first and the last beyond it).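

In this assay, 4-ethoxyphenyl in place of 2-methoxyphenyl on a saturated chain carbon bound to an oxygen on an aromatic ring stays within the scatter (a 1.9-fold lower number from compound 3 to compound 4 (0.29 log units; within the scatter)), and the same holds against the 2-chlorophenyl group (a 1.1-fold lower number from compound 2 to compound 4 (0.06 log units; within the scatter)). Against hydrogen, however, ethoxy gives a modest step beyond the scatter (a 3.8-fold lower number from compound 1 to compound 4 (0.58 log units; beyond the scatter)), making it the second substituent on this ring to do so after chloro (a 3.3-fold lower number from compound 1 to compound 2 (0.52 log units; beyond the scatter)), while the methoxy of compound 3 goes against this and stays within the scatter of compound 1. No evidence accompanies these steps that could explain them.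

The compounds shown leave open whether 4-methoxyphenyl or 2-ethoxyphenyl would read like compound 4, so the size of the alkoxy group and its place on the ring remain unseparated. On these data alone, how an amine or a carboxylic acid on this benzyl ring would read also remains open.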